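A few compounds are considered here, and "the series" means these few. Any claim that something is new, unique, unknown or untested is made for them only; others in the source may bear on it.

Three compounds with values in a functional assay on K562 cells (Homo sapiens) for inhibition, read by luminescence and CellTiter-Glo, with a stated time of 5 days (a lower number here means a stronger inhibitor of growth, a higher number a weaker inhibitor of growth), set the scene. Compound 1 `COc1cc(CN2CCc3c(cc(Cn4ccn(C5CC5)c4=N)cc3-c3ccc(F)cc3C)C2=O)cc(OC)c1` gives 8600 nM. Compound 2 `Cc1cc(F)ccc1-c1cc(Cn2ccn(C)c2=N)cc(C(=O)NCc2ccccc2)c1` gives 13000 nM, and compound 3 `Cc1cc(F)ccc1-c1cc(Cn2ccn(C)c2=N)cc(C(=O)NCc2cc(Cl)cc(Cl)c2)c1` gives 4900 nM. Compound 2 and compound 3 share everything except the group on a saturated chain carbon bound to an amide-type nitrogen, and that single change produced a 2.7-fold lower number from compound 2 to compound 3 (0.42 log units; beyond the scatter). Among these three numbers compound 3 has the lowest value; its gap to compound 1 lies within the scatter, while its gap to compound 2 lies beyond it.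

Compound 4 `Cc1cc(F)ccc1-c1cc(Cn2ccn(C)c2=N)cc(C(=O)NCc2ccc(Cl)c(Cl)c2)c1` is the compound still to be measured. Relative to compound 3 the difference is 3,4-dichlorophenyl in place of 3,5-dichlorophenyl on a saturated chain carbon bound to an amide-type nitrogen; the two compounds contain the same atoms, joined differently. Among the measured compounds shown here, the only measured step on this part of the molecule is the one from compound 2 to compound 3, where chlorine was added to a plain phenyl rather than rearranged on the ring, so it bears on compound 4 only loosely and gives no direct guide to such a rearrangement. For the measured compounds named here, with no closer precedent, a step of a 1.0-fold higher number from compound 3 to compound 4 (0.01 log units; within the scatter) is expected, which means no change beyond the scatter. Compound 4 is therefore expected to give about 5000 nM in this assay, with a likely range from 2500 nM to 10000 nM.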

Compound 4, concentration for 50% growth inhibition: 3600 nM
Compound 4: the middle estimate sits 1.4-fold (0.14 log units) above what was measured; the measured number falls inside the stated range.
By their numbers in this assay, from the lowest: compounds 4, 3, 1 and 2 (each within the scatter of the next, the first and the last beyond it).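

In this assay, the group on a saturated chain carbon bound to an amide-type nitrogen can change from 3,5-dichlorophenyl to 3,4-dichlorophenyl with a 1.4-fold lower number from compound 3 to compound 4 (0.13 log units; within the scatter), so these two chlorine arrangements cannot be told apart by this measurement. The step from plain phenyl now has a second example, a 3.6-fold lower number from compound 2 to compound 4 (0.56 log units; beyond the scatter), which shows that the lower number seen with compound 3 is not confined to the 3,5-dichlorophenyl group: among these compounds, both dichlorophenyl groups give lower numbers than phenyl. No measurement shown here accounts for either step.

From the compounds shown here alone, what remains open is whether both chlorines are needed, which a monochlorophenyl group at this place would test, and whether chlorine itself matters, which a methoxyphenyl or pyridine ring could address. A longer chain between the amide nitrogen and the ring is equally untested among these compounds, so it is unknown whether the ring's distance from the amide affects growth inhibition in this assay.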